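Swapping a Thiazole for a Halogenated Phenyl on the Sulfonyl

This account rests on a few compounds, and the source may have more. Where it says the series, first, only, none or still open, it means among the compounds named here.

Measured so far:
- compound 1, `Cc1nc(Cl)sc1S(=O)(=O)N1CCC(N2CCC(C)CC2)CC1`, 1.6 nM
- compound 2, `C#CCCC(=O)CC1CCN(C2CCN(S(=O)(=O)c3c(C)cc(C)cc3C)CC2)CC1`, 3 nM

Both compounds were tested in a functional assay on DLD-1 cells (Homo sapiens) for antiproliferative activity, read by CellTiter-Glo, with a stated time of 72 h; a lower number here means a stronger inhibitor, a higher number a weaker inhibitor. Compound 1 gives 1.6 nM, the lowest of the two numbers shown; compound 2, with 3 nM, lies close enough that the two values fall within the usual scatter of repeated measurements, so no order can be read between them. Both compounds share a core in which a sulfonyl group carries an aromatic ring, and in compound 2 that ring is a six-membered carbon ring, which shows that an all-carbon ring in this position is compatible with a low number.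

Compound 3, `CC1CCN(C2CCN(S(=O)(=O)c3ccc(Br)c(Cl)c3)CC2)CC1`, has not yet been measured. It differs from compound 1 in one place: 4-bromo-3-chlorophenyl in place of 2-chloro-4-methyl-1,3-thiazol-5-yl on a sulfonyl sulfur. Since compound 2 already carries a six-membered carbon ring on the sulfonyl and gives 3 nM, the change is expected to cost little. For compound 3 the expected step of a 1.9-fold higher number from compound 1 to compound 3 (0.27 log units; within the scatter) is small, perhaps a slight rise, and likely within the scatter. Compound 3 is therefore estimated at 3 nM, with a range from 1 nM to 12 nM.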

Compound 3, half-maximal inhibitory concentration: 12 nM
Estimate against measurement, compound 3: 4.0-fold (0.60 log units) below, and the stated range covers the measured number.
By their numbers in this assay, from the lowest: compounds 1 and 2 (each within the scatter of the next); then compound 3.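

In this assay, within the data shown here, this is the first comparison that changes only one place: 4-bromo-3-chlorophenyl in place of 2-chloro-4-methyl-1,3-thiazol-5-yl on the sulfonyl sulfur gives a 7.5-fold higher number from compound 1 to compound 3 (0.88 log units; beyond the scatter), so the group at this position does affect the number and the two rings are not interchangeable. The rise is modest, however, and compound 3 still gives 12 nM, which shows that a low number here does not depend on a ring with hetero atoms. No measurement shown bears on the cause of the rise.

The swap alters the ring size, the hetero atoms and the halogens all at once, so the share of each in the step cannot be separated from these compounds. A plain phenyl ring, a phenyl ring carrying only the bromine or only the chlorine, and a thiazole without its methyl group would each isolate one part of the change, while a pyridine ring would show how a ring nitrogen fares at this position.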